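This account rests on a few compounds, and the source may have more. Where it says the series, first, only, none or still open, it means among the compounds named here.

Of the compounds shown here, three built on one shared core have been measured in an assay on isolated protein for displacement of a labelled ligand from melanin-concentrating hormone receptor 1 (Homo sapiens); a higher number here means a weaker inhibitor, a lower number a stronger inhibitor. Compound 1 `CCCc1cc(N)c2cc(NC(=O)/C=C/c3ccc(C(C)(C)C)cc3)ccc2n1` gives 22 nM. Compound 2 `CCCc1cc(N)c2cc(NC(=O)c3ccc(-c4ccc(Cl)cc4)cc3)ccc2n1` gives 0.7 nM, and compound 3 `CCCc1cc(N)c2cc(NC(=O)C3CCC(c4ccc(Cl)cc4)CC3)ccc2n1` gives 4.4 nM. Compound 1 therefore stands highest of the three numbers, making it the weakest binder of the set: compound 3 lies nearest to it and compound 2 furthest, and both gaps are beyond the usual scatter.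

Compound 4 `CCCc1cc(N)c2cc(NC(=O)/C=C/c3ccccc3)ccc2n1` is derived from compound 1 by one change, (hydrogen in place of tert-butyl on an aromatic carbon). The only difference is the loss of the tert-butyl group from the outer ring. Among the measured compounds shown here, every measured compound carries a group on that ring, so there is no measured pair showing what removal of such a group does. A loss of binding strength beyond the scatter is nevertheless expected, since compound 1 already gives the weakest number in this assay at 22 nM. The step from compound 1 to compound 4 is expected to be a 5.0-fold higher number from compound 1 to compound 4 (0.70 log units; beyond the scatter). For compound 4 the estimate is 110 nM, within a range from 30 nM to 450 nM.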

Compound 4, half-maximal inhibitory concentration: 1000 nM
For compound 4 the middle estimate is 9.1-fold (0.96 log units) below the measured one, and the stated range ends below it.
By their numbers in this assay, from the lowest: compound 2; then compound 3; then compound 1; then compound 4.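

In this assay, putting hydrogen in place of tert-butyl on this aromatic carbon gives a 45-fold higher number from compound 1 to compound 4 (1.66 log units; beyond the scatter), a large loss of binding strength from a single change. Among the compounds shown here, every earlier compound carried a group on this ring, so only this pair shows that the position cannot simply be left bare: much of the binding strength of compound 1 disappears without the tert-butyl. Nothing measured here explains why the loss is so large.

As far as these compounds go, it remains open how much of the lost binding a smaller group on the same carbon, such as a methyl or a methoxy group, would restore, and how a carboxylic acid there would fare. Also open, from the compounds shown here alone, is whether removing the chlorine from compound 2 would cost a similar amount.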